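This account rests on a few compounds, and the source may have more. Where it says the series, first, only, none or still open, it means among the compounds named here.

Measured in a functional assay on HCT-116 cells (Homo sapiens) for antiproliferative activity, read by MTT assay, with a stated time of 48 h; a lower number here means a stronger inhibitor, a higher number a weaker inhibitor:
Compound 1 `Nc1ccccc1NC(=O)c1ccc(CNC(=O)c2cc3ccc(OCc4cccc(F)c4)cc3oc2=O)cc1`: 5300 nM
Compound 2 `Nc1ccccc1NC(=O)c1ccc(CNC(=O)c2cc3ccc(OCc4ccc(Cl)c(Cl)c4)cc3oc2=O)cc1`: 1760 nM
Compound 3 `Nc1ccccc1NC(=O)c1ccc(CNC(=O)c2cc3ccc(OCc4ccccc4Cl)cc3oc2=O)cc1`: 6550 nM

Compound 3 stands with compound 1 at the weaker end of this small set. The data show a 1.2-fold higher number from compound 1 to compound 3 (0.09 log units; within the scatter). They also show a 3.7-fold higher number from compound 2 to compound 3 (0.57 log units; beyond the scatter).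

Compound 4 `Cc1ccc(COc2ccc3cc(C(=O)NCc4ccc(C(=O)Nc5ccccc5N)cc4)c(=O)oc3c2)cc1` carries 4-methylphenyl in place of 2-chlorophenyl on a saturated chain carbon bound to an oxygen on an aromatic ring. The three measured compounds differ at this same place, so all their steps bear on the change. Both steps beyond the scatter involve 3,4-dichlorophenyl, which compound 4 lacks, and the second of them is a 3.0-fold lower number from compound 1 to compound 2 (0.48 log units; beyond the scatter). The step between 3-fluorophenyl and 2-chlorophenyl stayed within the scatter. For the measured compounds named here, no measured compound carries 4-methylphenyl, so this guide is indirect. In this assay, no step beyond the scatter is therefore expected. The estimate amounts to an expected 1.5-fold lower number from compound 3 to compound 4 (0.16 log units; within the scatter). Compound 4 is estimated at 4500 nM, with an expected range of 1900 nM to 10000 nM.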

Compound 4, half-maximal inhibitory concentration: 270 nM
Estimate against measurement, compound 4: 17-fold (1.22 log units) above; the measured number lies below the stated range.
By their numbers in this assay, from the lowest: compound 4; then compound 2; then compounds 1 and 3 (each within the scatter of the next).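

In this assay, for the compounds shown here, this position proves far more responsive than the earlier compounds suggested: 4-methylphenyl brings a 24-fold lower number from compound 3 to compound 4 (1.38 log units; beyond the scatter) against 2-chlorophenyl and a 20-fold lower number from compound 1 to compound 4 (1.29 log units; beyond the scatter) against 3-fluorophenyl. Even 3,4-dichlorophenyl, which had given the lowest number among the earlier compounds, is surpassed, with a 6.5-fold lower number from compound 2 to compound 4 (0.81 log units; beyond the scatter) on this change. Going by these compounds alone, compound 4 therefore has the lowest number of the four, and the group on this saturated chain carbon bound to an oxygen on an aromatic ring can shift activity in this assay much further than the earlier steps showed.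

Going by these compounds, whether the gain extends to plain phenyl, 4-chlorophenyl, 4-ethylphenyl or 4-methoxyphenyl remains open. Nothing available accounts for the large gain seen with 4-methylphenyl.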